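Hydroxy for Fluoro on the Benzyl Ring of Compound 3

The source may hold more compounds than are shown below. What is called first, only, known or untested is meant among the compounds shown, and "the series" means these compounds.

Measured compounds:
Compound 1 `COc1cc(C(=O)N2CCC(O)C(C)C2)cc2nc(NCc3cccc(Cl)c3)oc12` — in an assay on isolated protein for inhibition of thyroid hormone receptor beta (Homo sapiens), read by fluorescence, with a stated time of 30 min (on this read-out lower numbers stand for stronger inhibition and higher numbers for weaker inhibition), compound 1 gives 25 nM.
Compound 2 `COc1cc(C(=O)N2CCC(O)C(C)C2)cc2nc(NCc3cncc(Cl)c3)oc12` — in this assay compound 2 gives 7200 nM.
Compound 3 `COc1cc(C(=O)N2CCC(O)C(C)C2)cc2nc(NCc3cc(Cl)ccc3F)oc12` — in this assay compound 3 gives 300 nM.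

Compound 3 sits between the other two: it shows a 12-fold higher number from compound 1 to compound 3 (1.08 log units; beyond the scatter) and a 24-fold lower number from compound 2 to compound 3 (1.38 log units; beyond the scatter), so it is neither the strongest nor the weakest of the three in this assay.

Compound 4 `COc1cc(C(=O)N2CCC(O)C(C)C2)cc2nc(NCc3cc(Cl)ccc3O)oc12` differs from compound 3 in one place: hydroxy in place of fluoro on an aromatic carbon. Within the data shown here, no measured step exchanges these two groups, so the bearing steps are indirect. The step of a 12-fold higher number from compound 1 to compound 3 (1.08 log units; beyond the scatter) shows that placing a fluoro on this carbon costs a large amount, and a 290-fold higher number from compound 1 to compound 2 (2.46 log units; beyond the scatter) shows that changing the ring itself costs far more. From the compounds shown here alone, replacing the fluoro with hydroxy leaves the ring intact, so a large loss is not expected, but the new group is untested here and the direction is uncertain.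

Compound 4 is therefore expected to stay close to compound 3 in this assay, the estimated step being a 1.3-fold higher number from compound 3 to compound 4 (0.12 log units; within the scatter). The estimate for compound 4 is 400 nM, ranging from 80 nM to 2500 nM.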

Compound 4, half-maximal inhibitory concentration: 170 nM
Estimate against measurement, compound 4: 2.4-fold (0.37 log units) above; the measured number falls inside the stated range.
By their numbers in this assay, from the lowest: compound 1; then compounds 4 and 3 (each within the scatter of the next); then compound 2.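

In this assay, hydroxy in place of fluoro on this aromatic carbon gives a 1.8-fold lower number from compound 3 to compound 4 (0.25 log units; within the scatter) and so stays within the scatter, although hydroxy brings one hydrogen-bond donor and one hydrogen-bond acceptor and fluoro brings neither. Hydroxy in place of hydrogen on the same carbon gives a 6.8-fold higher number from compound 1 to compound 4 (0.83 log units; beyond the scatter) and lies beyond the scatter, so the loss against compound 1 is now seen with two different groups rather than with fluoro alone. The 5-chloro-2-hydroxyphenyl group also keeps a wide margin over 5-chloropyridin-3-yl, with a 42-fold lower number from compound 2 to compound 4 (1.63 log units; beyond the scatter) as the step.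

Nothing at hand accounts for these numbers. From the compounds shown here alone, it stays open whether a methoxy group or an amine on this carbon would match fluoro and hydroxy or return the value toward that of compound 1.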